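The compounds below may be only part of what the source reports. "The series", "measured", "known", "first", "only" and "open" are said of these compounds alone.

Three compounds share one core, and they are ranked here in an assay for inhibition of Dihydrofolate reductase (Homo sapiens); on this read-out higher numbers stand for higher potency (the scale is a negative logarithm) and lower numbers for lower potency. Compound 1, `Sc1nc(S)c2cc(Sc3ccc4ccccc4c3)ccc2n1`, gives 5.05. Compound 2, `Nc1nc(S)c2cc(Sc3ccc4ccccc4c3)ccc2n1`, gives 6.64. Compound 3, `Nc1nc(O)c2cc(Sc3ccc4ccccc4c3)ccc2n1`, gives 7.35, which is the highest of the three numbers: its step to compound 2 is beyond the scatter, and its step to compound 1 is beyond the scatter as well, so compound 3 is the most potent of the measured set.

The next compound, compound 4, is `Oc1nc(S)nc2ccc(Sc3ccc4ccccc4c3)cc12`. The change from compound 3 is sulfanyl in place of amino on an aromatic carbon. For the measured compounds named here, only one measured step bears on it directly, and it runs the opposite way: a number 1.59 log units higher from compound 1 to compound 2 (beyond the scatter), with amino in place of sulfanyl at the same place between two ring nitrogen atoms. The other step, a number 0.71 log units higher from compound 2 to compound 3 (beyond the scatter), concerns the hydroxy group, which compound 4 keeps, so it does not speak to the change under study.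

Because the step of a number 1.59 log units higher from compound 1 to compound 2 (beyond the scatter) was large, the reverse exchange in compound 4 is expected to cost about as much, giving an expected step of a number 1.55 log units lower from compound 3 to compound 4 (beyond the scatter). Compound 4 is therefore estimated at 5.8, with a range from 5 to 6.6.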

Compound 4, logarithm of the reciprocal of the active concentration, log(1/C): 5
Beside the measured number, compound 4's estimate is 0.80 log units above it, within the range that was stated.
By their numbers in this assay, from the lowest: compounds 4 and 1 (each within the scatter of the next); then compound 2; then compound 3.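

In this assay, the exchange on the aromatic carbon between two ring nitrogen atoms can now be read with the hydroxy group present, where sulfanyl in place of amino gives a number 2.35 log units lower from compound 3 to compound 4 (beyond the scatter), so the size of this exchange depends on the group it is paired with: the same change on two cores in this assay, a number 1.59 log units higher (beyond the scatter) from compound 1 to compound 2 and a number 2.35 log units higher (beyond the scatter) from compound 4 to compound 3, 0.76 log units apart, beyond the scatter of two such steps

The exchange of hydroxy for sulfanyl depends on its partner as well, since with sulfanyl on that aromatic carbon it gives a number 0.05 log units lower from compound 1 to compound 4 (within the scatter), and its only step beyond the scatter comes with amino there: the same change on two cores in this assay, a number 0.71 log units higher (beyond the scatter) from compound 2 to compound 3 and a number 0.05 log units lower (within the scatter) from compound 1 to compound 4, 0.76 log units apart, beyond the scatter of two such steps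

Across these four compounds the two exchanges therefore do not act independently, and it is the pairing of amino with hydroxy in compound 3 that gives 7.35.

Going by these compounds, whether a methylamino group or a plain hydrogen on that aromatic carbon could keep the number of compound 3 remains open. So does how a methoxy group in place of the hydroxy group would behave when paired with amino, and whether the same dependence on the partner group would hold there.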